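The source may hold more compounds than are shown below. What is called first, only, known or untested is meant among the compounds shown, and "the series" means these compounds.

In a functional assay on HL-60 cells (Homo sapiens) for cytotoxicity, read by CCK-8 assay, with a stated time of 24 h (a higher number here means a weaker inhibitor, a lower number a stronger inhibitor), three compounds have been measured. Compound 1 (`C=CC(=O)N1C(=O)CC(c2ccc(Br)cc2)Sc2ccccc21`) gives 126000 nM, compound 2 (`C=CC(=O)N1C(=O)CC(c2ccc(Cl)cc2)Sc2ccccc21`) gives 95700 nM, and compound 3 (`C=CC(=O)N1C(=O)CCSc2ccccc21`) gives 44800 nM. Compound 3 thus has the lowest number of the three, and its distance to each of the others is beyond the scatter.

The next compound, compound 4 (`C=CC(=O)N1C(=O)CC(c2ccccc2Cl)Sc2ccccc21`), departs from compound 3 by 2-chlorophenyl in place of hydrogen on a saturated ring carbon, next to the ring sulfur. Among the measured compounds shown here, two measured steps bear on this change when read in reverse, since each puts hydrogen in place of a halogen-bearing phenyl group at that carbon. They are a 2.1-fold lower number from compound 2 to compound 3 (0.33 log units; beyond the scatter) and a 2.8-fold lower number from compound 1 to compound 3 (0.45 log units; beyond the scatter), both modest. A third step, a 1.3-fold lower number from compound 1 to compound 2 (0.12 log units; within the scatter), shows that exchanging the halogen moved the number only within the scatter. For the measured compounds named here, no measured compound carries the chlorine as it stands in 2-chlorophenyl, so that part of the change remains untested.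

Going by compound 2 and compound 1, a modest move towards a higher number is expected, with the estimated step being a 2.1-fold higher number from compound 3 to compound 4 (0.33 log units; beyond the scatter). In this assay, compound 4 is estimated at 95000 nM, with an expected range from 48000 nM to 180000 nM.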

Compound 4, half-maximal inhibitory concentration: 91400 nM
For compound 4 the middle estimate is 1.0-fold (0.02 log units) above the measured one; low and high end bracket the measured number.
By their numbers in this assay, from the lowest: compound 3; then compounds 4, 2 and 1 (each within the scatter of the next).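

In this assay, the placement of the chlorine on the phenyl ring, untested until now, can be read directly: a 1.0-fold lower number from compound 2 to compound 4 (0.02 log units; within the scatter) lies within the scatter, so 2-chlorophenyl and 4-chlorophenyl cannot be told apart at this saturated ring carbon next to the ring sulfur. The comparison with the bromine-bearing compound gives the same reading, as a 1.4-fold lower number from compound 1 to compound 4 (0.14 log units; within the scatter) also lies within the scatter. Against hydrogen, the new substituent gives a 2.0-fold higher number from compound 3 to compound 4 (0.31 log units; beyond the scatter), beyond the scatter though modest, so all three halogen-bearing phenyl compounds now stand on the higher side of compound 3, and none of the four compounds goes against this.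

The compounds shown leave open whether the step depends on the halogen at all, which a plain phenyl group would address, and whether an amine, a carboxylic acid or a longer alkyl chain at this same carbon would give a number near that of compound 3 or near those of the halogen-bearing phenyl compounds. No evidence bearing on this result accompanies these measurements, so the step from hydrogen to 2-chlorophenyl stands without an explanation.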